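A few compounds are considered here, and "the series" means these few. Any claim that something is new, unique, unknown or untested is made for them only; others in the source may bear on it.

Measured so far:
- compound 1 `C[C@@H](CC(=O)O)CC(=O)c1c([C@@H](O)CCCCCc2ccccc2)n(C)c2ccc(Cl)cc12`: 120 nM
- compound 2 `C[C@@H](CC(=O)O)CC(=O)c1c([C@H](O)CCCCCc2ccccc2)n(C)c2ccc(Cl)cc12`: 750 nM

In a functional assay for antagonist activity at Oxoeicosanoid receptor 1 (Homo sapiens), read by fluorescence and calcium flux, with stated times of 2 min and 1 min (on this read-out lower numbers stand for stronger inhibition and higher numbers for weaker inhibition), compound 2 gives the higher of the two numbers shown, with compound 1 the only neighbour. Among the compounds with values here, the single measured step is a 6.3-fold higher number from compound 1 to compound 2 (0.80 log units; beyond the scatter), and it rests on (the fact that compounds 1 and 2 differ only in the configuration as drawn), so a change of configuration alone can move the read-out noticeably here.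

Compound 3 `C[C@H](CC(=O)O)CC(=O)c1c([C@H](O)CCCCCc2ccccc2)n(C)c2ccc(Cl)cc12` is the next pair member. It differs from compound 2 only in this way: the two compounds have the same atoms and bonds and differ only in configuration as drawn: 1 of 2 stereo elements differ; a stereocentre at a saturated chain carbon is drawn R in compound 2 and S in compound 3. Within the data shown here, this is a different stereocentre from the one that separates compound 1 and compound 2, so the measured step does not show the direction for this change; it shows only that configuration matters. The expected step from compound 2 to compound 3 is therefore uncertain in sign, a 1.2-fold lower number from compound 2 to compound 3 (0.06 log units; within the scatter), with a wide range. Compound 3 is estimated at 650 nM, between 150 nM and 3000 nM.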

Compound 3, half-maximal inhibitory concentration: 260 nM
Beside the measured number, compound 3's estimate is 2.5-fold (0.40 log units) above it, within the range that was stated.
By their numbers in this assay, from the lowest: compound 1; then compound 3; then compound 2.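

In this assay, the second stereocentre matters too: inverting it, with the first held as in compound 2, gives a 2.9-fold lower number from compound 2 to compound 3 (0.46 log units; beyond the scatter), so the number responds to both stereocentres and not only to the one seen earlier. Compound 1 and compound 3 are mirror images, and inverting both stereocentres together gives a 2.2-fold higher number from compound 1 to compound 3 (0.34 log units; beyond the scatter), a smaller move than inverting the first stereocentre alone. All of these differences arise without any change in atoms or bonds, as the gap between the mirror images shows: the fact that compounds 1 and 3 differ only in the configuration as drawn.

The compounds shown leave open how the remaining combination of the two stereocentres would read. They also leave open whether the same preference would hold with a methyl ester in place of the carboxylic acid, or with a longer chain ending in the phenyl ring.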